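The source may hold more compounds than are shown below. What is called first, only, known or untested is meant among the compounds shown, and "the series" means these compounds.

Measured compounds in this series:

- compound 1 `CCCCN(CC)c1nc(C)nc2c(-c3ccc(OC)nc3C)c(C)nn12` — 4.9 nM
- compound 2 `CCC(CC)Nc1nc(C)nc2c(-c3cnc(N(C)C)cc3C)c(C)nn12` — 24.8 nM
- compound 3 `CCN(CC)c1nc(C)nc2c(-c3c(C)cc(N(C)C)nc3C)c(C)nn12` — 58 nM

In an assay on cell membranes for displacement of a labelled ligand from corticotropin-releasing factor receptor 1 (Rattus norvegicus) (a higher number here means a weaker inhibitor, a lower number a stronger inhibitor), compound 1 gives 4.9 nM, the lowest number of the three. Compound 2 stands next with 24.8 nM, a gap beyond the scatter, and compound 3 is furthest away at 58 nM, also beyond the scatter. Within the data shown here, compound 1 is therefore the strongest inhibitor among the measured set; no single-point steps connect these three, since each differs from the others in more than one place.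

Compound 4 `CCCC(C)Nc1nc(C)nc2c(-c3ccc(OC)nc3C)c(C)nn12` keeps the aryl group and the core of compound 1 and differs only at the amine: (1-methylbutyl)amino in place of butyl(ethyl)amino on an aromatic carbon. Compound 2 already carries a secondary, branched amine of this kind at the same position of the core and still reaches 24.8 nM with a different aryl, so a secondary branched amine is compatible with tight binding in this assay. Among the measured compounds shown here, no measured pair isolates this exact change, so the expectation is a step near or within the scatter, if anything toward a slightly higher number.

Compound 4 is estimated at 8 nM, with a range of 2.5 nM to 25 nM. This estimate corresponds to an expected step of a 1.6-fold higher number from compound 1 to compound 4 (0.21 log units; within the scatter).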

Compound 4, half-maximal inhibitory concentration: 3.5 nM
Estimate against measurement, compound 4: 2.3-fold (0.36 log units) above; the range from low to high includes it.
By their numbers in this assay, from the lowest: compounds 4 and 1 (each within the scatter of the next); then compound 2; then compound 3.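

With the aryl group and the shared core held fixed, (1-methylbutyl)amino in place of butyl(ethyl)amino gives a 1.4-fold lower number from compound 1 to compound 4 (0.15 log units; within the scatter) in this assay, so on this aromatic carbon the two amines cannot be told apart. The earlier compounds shown here could not show this, since none of them formed a pair differing in one place, and compound 2 offered only indirect support for a branched amine of this kind. The step also shows that the hydrogen-bond donor present in (1-methylbutyl)amino and absent from butyl(ethyl)amino comes with no change beyond the scatter in this series, although no measurement at hand explains why the two amines read alike.

From the compounds shown here alone, whether the same exchange would read alike with the aryl groups of compound 2 and compound 3 stays open, as each of these differs from compound 1 in more than one place. Also open, going by these compounds, is how far this position accepts other amines, such as a cyclopropylmethylamino group, a longer branched chain or a chain ending in a methoxy ether.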